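The source may hold more compounds than are shown below. What is called first, only, known or untested is meant among the compounds shown, and "the series" means these compounds.

Measured compounds:
compound 1, `NCCNc1c(C(=O)NCc2ccc(F)cc2)nc(Br)c2cccnc12`: in a toxicity assay on C8166 cells (Homo sapiens) for cytotoxicity, read by MTT assay, with a stated time of 72 h (a higher number here means that more compound is tolerated, a lower number that less compound is tolerated), compound 1 gives "not determined" (no result reported)
compound 2, `CS(=O)(=O)NCCCCCCN(c1nc(C(=O)NCc2ccc(F)cc2)c(O)c2ncccc12)S(C)(=O)=O`: in this assay compound 2 gives 37000 nM

Compound 1 stands without a number in this assay, so there is no measured anchor for it. Compound 3, `Cc1ccc(S(=O)(=O)Oc2c(C(=O)NCc3ccc(F)cc3)nc(Br)c3cccnc23)cc1`, differs from compound 1 by ((4-methylphenyl)sulfonyl)oxy in place of (2-aminoethyl)amino on an aromatic carbon. Going by the values given here, no step between measured compounds is known, so the size of the change cannot be read from the data; no shift beyond the usual scatter is assumed in either direction. For compound 3 the value in this assay is estimated at 40000 nM, with an expected range of 10000 nM to 160000 nM.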

Compound 3, half-maximal cytotoxic concentration: 31000 nM
Estimate against measurement, compound 3: 1.3-fold (0.11 log units) above; the measured number falls inside the stated range.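

Going by these compounds alone, compound 1 gives "not determined" (no result reported) in this assay, so no step to compound 3 can be read. From the compounds shown here alone, whether ((4-methylphenyl)sulfonyl)oxy in place of (2-aminoethyl)amino shifts tolerance on the shared core stays open. No evidence bears on this result.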